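Swapping a Bromophenyl for a Methylthiophene on the Alkene

The compounds below may be only part of what the source reports. "The series", "measured", "known", "first", "only" and "open" are said of these compounds alone.

In a functional assay on DU-145 cells (Homo sapiens) for inhibition, read by trypan blue exclusion, with a stated time of 96 h (a higher number here means a weaker inhibitor of growth, a lower number a stronger inhibitor of growth), compound 2 `Cc1ccc(/C=C(\C(=O)c2ccc(Cl)cc2)S(=O)(=O)Cc2ccc(Cl)cc2)s1` gives 1000 nM. Compound 1 `Cc1ccc(/C=C(\C(=O)c2ccc(Cl)cc2)S(=O)(=O)Cc2ccc(Cl)cc2Cl)s1` gives 10000 nM in this assay. Within the data shown here, the step of a 10-fold lower number from compound 1 to compound 2 (1.00 log units; beyond the scatter) is the only change here with two measured ends, and it touches the benzyl sulfone side of the shared core. Compound 3 `O=C(/C(=C\c1ccc(Br)cc1)S(=O)(=O)Cc1ccc(F)cc1)c1ccc(Cl)cc1` gives only > 100000 nM, which is a limit of this assay and not a number (the limit of > 100000 nM in this assay, at which 1 of the 3 values shown sits). Compound 4 `Cc1ccc(/C=C(\C(=O)c2ccc(Cl)cc2)S(=O)(=O)Cc2ccc(F)cc2)s1` has not yet been measured in this assay. It differs from compound 3 in one place: 5-methylthiophen-2-yl in place of 4-bromophenyl on a double-bonded chain carbon bound to a double-bonded chain carbon. Among the measured compounds shown here, no measured step changes this part of the molecule; the move has no direct precedent. For the measured compounds named here, the one hint is that compounds 1 and 2 both carry the 5-methylthiophen-2-yl group and return numbers, while compound 3 with the 4-bromophenyl group sits at the limit. Compound 4 is therefore expected to return a number, estimated at 3000 nM, within 500 nM to 30000 nM. That estimate means an expected step of an at least 33-fold lower number from compound 3 to compound 4 (1.52 log units; beyond the scatter) toward stronger growth inhibition, held with little confidence.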

Compound 4, concentration for 50% growth inhibition: 50000 nM
Estimate against measurement, compound 4: 17-fold (1.22 log units) below, and the stated range ends below it.
By their numbers in this assay, from the lowest: compound 2; then compound 1; then compound 4. At a limit, above all of these: compound 3.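

Compound 3 gives > 100000 nM, which is a limit of this assay and not a number. The change of 4-bromophenyl to 5-methylthiophen-2-yl on the double-bonded chain carbon can therefore be read only as an at least 2.0-fold lower number from compound 3 to compound 4 (0.30 log units; that floor lies within the scatter), so this result does not establish a real gain from the swap. The 5-methylthiophen-2-yl group also does not by itself give strong growth inhibition, since changes on the benzyl sulfone side still move the number clearly, with a 50-fold higher number from compound 2 to compound 4 (1.70 log units; beyond the scatter) for fluoro in place of chloro and a 5.0-fold higher number from compound 1 to compound 4 (0.70 log units; beyond the scatter) for 4-fluorophenyl in place of 2,4-dichlorophenyl.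

From the compounds shown here alone, it remains open how 4-bromophenyl would behave with the benzyl sulfone groups of compound 1 or compound 2. Also open, going by these compounds, is how this alkene position would respond to other groups, such as an unsubstituted phenyl or a phenyl carrying an amine.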